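The source may hold more compounds than are shown below. What is called first, only, known or untested is meant among the compounds shown, and "the series" means these compounds.

Compound 1 `Cc1ccccc1Cn1c(CN2CCN(C(=O)C3CC3)CC2)nc2ccccc21`: 29.1%
Compound 2 `CC(C)CCn1c(OC2CCN(C(=O)c3ccco3)CC2)nc2ccccc21`: 30.8%

In an assay on isolated protein for inhibition of aldehyde dehydrogenase 1A1 (Homo sapiens), read by spectrophotometry, tested at 10 uM (a lower number here means less inhibition, a higher number more inhibition at the concentration tested (going by the name of the read-out)), compound 1 gives 29.1%; compound 2 gives 30.8% in this assay, and the two numbers lie within the scatter of each other, so neither compound is set apart. Compound 3 `O=C(C1CC1)N1CCN(Cc2nc3ccccc3n2Cc2ccccc2)CC1` is not yet measured. It differs from compound 1 by hydrogen in place of methyl on an aromatic carbon. Going by the values given here, no measured pair shows this same change, so its size has no precedent here. Removal of the methyl is expected to give a step of a number 4.1 percentage points lower from compound 1 to compound 3 (within the scatter), not beyond the scatter. Compound 3 is accordingly estimated at 25%, within 10% to 40%.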

Compound 3, a percentage reported as inhibition, at one concentration (the size of the read-out at that concentration, not a potency): 23.9%
Beside the measured number, compound 3's estimate is 1.1 percentage points above it, and the stated range covers the measured number.
By their numbers in this assay, from the lowest: compounds 3, 1 and 2 (each within the scatter of the next).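

In this assay, the change from 2-methylbenzyl to benzyl gives a number 5.2 percentage points lower from compound 1 to compound 3 (within the scatter) and so the methyl on this aromatic carbon can go without a step beyond the scatter. Going by these compounds alone, this is the first pair that differs in one place, and at this position it sets no measurable value on the methyl. Nothing measured bears on the cause of this step.

Open, as far as these compounds go, is whether a larger group at this place, such as methoxy or chlorine, would give a step beyond the scatter. Also open, from the compounds shown here alone, is whether an amine or a carboxylic acid at this place would do so.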